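Swapping the Aryl Ether for a Dichlorophenyl Thioether

This account rests on a few compounds, and the source may have more. Where it says the series, first, only, none or still open, it means among the compounds named here.

Of the compounds shown here, three built on one shared core have been measured in an assay on HEK293 cells for displacement of a labelled ligand from Melanocortin receptor 4 (Homo sapiens); on this read-out lower numbers stand for stronger inhibition and higher numbers for weaker inhibition. Compound 1 `Cc1ccc(OCC(=O)N2CCN(c3ccc(C(F)(F)F)cc3[C@@H](N)CC(C)C)CC2)cc1` gives 4400 nM in this assay, compound 2 `CC(C)C[C@H](N)c1cc(C(F)(F)F)ccc1N1CCN(C(=O)COc2ccc(O)cc2)CC1` gives 4600 nM, and compound 3 `CC(C)C[C@H](N)c1cc(C(F)(F)F)ccc1N1CCN(C(=O)COc2cccc(Cl)c2)CC1` gives 2600 nM. Compound 3 holds the lowest of the three numbers, yet the steps of a 1.7-fold lower number from compound 1 to compound 3 (0.23 log units; within the scatter) and a 1.8-fold lower number from compound 2 to compound 3 (0.25 log units; within the scatter) both fall within the scatter, so the three compounds stand level in this assay. The step of a 1.0-fold higher number from compound 1 to compound 2 (0.02 log units; within the scatter) likewise moved nothing beyond the scatter.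

Compound 4 `CC(C)C[C@H](N)c1cc(C(F)(F)F)ccc1N1CCN(C(=O)CSc2ccc(Cl)cc2Cl)CC1` carries (2,4-dichlorophenyl)sulfanyl in place of 3-chlorophenoxy on a saturated chain carbon bound to a carbonyl carbon. The two measured steps that bear on this change altered only the substituents on the same aryl ring and left the numbers essentially where they were; no measured compound replaces the oxygen by sulfur, so that part of the change has no precedent among these three. The step is therefore expected to be a 1.4-fold lower number from compound 3 to compound 4 (0.16 log units; within the scatter), a shift not beyond the scatter in either direction. Compound 4 is accordingly estimated at 1800 nM, within a range from 600 nM to 6000 nM.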

Compound 4, inhibition constant: 1500 nM
The estimate for compound 4 lay 1.2-fold (0.08 log units) above the measured number, and the stated range covers the measured number.
By their numbers in this assay, from the lowest: compounds 4, 3, 1 and 2 (each within the scatter of the next, the first and the last beyond it).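

Among the compounds shown here, only the steps into compound 4 pass beyond the scatter in this assay, with a 3.1-fold lower number from compound 2 to compound 4 (0.49 log units; beyond the scatter) and a 2.9-fold lower number from compound 1 to compound 4 (0.47 log units; beyond the scatter), both modest. Yet a 1.7-fold lower number from compound 3 to compound 4 (0.24 log units; within the scatter) stays within the scatter, so (2,4-dichlorophenyl)sulfanyl on a saturated chain carbon bound to a carbonyl carbon separates compound 4 from the 4-hydroxyphenoxy and 4-methylphenoxy compounds but not from the 3-chlorophenoxy compound. Nothing available bears on why these numbers differ.

The change swaps the linking atom and alters the chlorine pattern together, so the compounds shown cannot say how much of the shift belongs to the sulfur and how much to the chlorines; 2,4-dichlorophenoxy and 3-chlorophenylsulfanyl would part the two. Also open, going by these compounds, is how this position responds to a group of another kind, such as a carboxylic acid or an amine.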